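Three Anilines at the Limit, a Fourth Awaits

The compounds below may be only part of what the source reports. "The series", "measured", "known", "first", "only" and "open" are said of these compounds alone.

Compound 3, `COc1cc(Nc2ncc(C(F)(F)F)c(N3Cc4cccc(N(C)S(C)(=O)=O)c4C3)n2)c(OC)cc1Cl`, was tested in a functional assay on OVCAR-3 cells (Homo sapiens) for antiproliferative activity, read by spectrophotometry, with a stated time of 2 days; a higher number here means a weaker inhibitor of growth, a lower number a stronger inhibitor of growth. In this assay compound 3 reached only the limit of > 30000 nM, so no number is known for it. Its two companions are compound 1, `COc1ccc(Nc2ncc(C(F)(F)F)c(N3Cc4cccc(N(C)S(C)(=O)=O)c4C3)n2)cc1C(F)(F)F`, and compound 2, `Cc1cc(Cl)ccc1Nc1ncc(C(F)(F)F)c(N2Cc3cccc(N(C)S(C)(=O)=O)c3C2)n1`. In this assay compound 1 also stopped at the limit of > 30000 nM. Compound 2 gave the limit of > 30000 nM in this assay as well. The steps between them therefore cannot be read: a step that the two limits leave unreadable from compound 1 to compound 2, a step that the two limits leave unreadable from compound 1 to compound 3 and a step that the two limits leave unreadable from compound 2 to compound 3. The whole picture rests on (the limit of > 30000 nM in this assay, at which 3 of the 3 values shown sit), which puts every measured value at the same edge of the assay.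

Compound 4, `COc1cc(Nc2ncc(C(F)(F)F)c(N3Cc4cccc(N(C)S(C)(=O)=O)c4C3)n2)cc(C(F)(F)F)c1`, differs from compound 3 in one place: 3-methoxy-5-(trifluoromethyl)phenyl in place of 4-chloro-2,5-dimethoxyphenyl on a nitrogen on an aromatic ring. Among the measured compounds shown here, no measured step bears on this change, and none of the three earlier changes on this nitrogen moved any compound off the limit. Compound 4 is therefore expected to behave like the others, with an estimated step of a number no higher from compound 3 to compound 4 (the limit leaves the size open). The estimate for compound 4 in this assay is 30000 nM, within a range from 8000 nM to 100000 nM.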

Compound 4, concentration for 50% growth inhibition: > 30000 nM
Compound 4: a limit, no number; the forecaster's own chance of this, stated with the estimate: 70%; the middle value sits exactly at the limit.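

Compound 4 gave only a limit in this assay, not a number, so its steps to compound 1, compound 2 and compound 3 cannot be read: the limit of > 30000 nM in this assay, at which 4 of the 4 values shown sit.

The compounds shown leave open how strongly, if at all, any of them inhibits growth, and whether the group on this nitrogen matters.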